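The source may hold more compounds than are shown below. What is called first, only, known or untested is meant among the compounds shown, and "the series" means these compounds.

Of the compounds shown here, three sharing one core have been tested in an assay on isolated protein for inhibition of DNA topoisomerase 1 (Homo sapiens), with a stated time of 30 min, tested at 100 uM; a higher number here means a stronger effect of the compound at the concentration tested, a lower number a weaker effect. Compound 1 `Oc1ccc(-c2cc(-c3cccnc3)nc(-c3ccccc3Cl)c2)cc1` gives 0.9% in this assay. Compound 2 `Oc1cccc(-c2cc(-c3ccc(Cl)cc3)nc(-c3ccco3)c2)c1` gives 27.1% in this assay. Compound 3 `Oc1cccc(-c2cc(-c3ccncc3)nc(-c3ccccc3Cl)c2)c1` gives 0% in this assay, the lowest of the three numbers; compound 1 sits within the scatter of it, while compound 2 lies beyond the scatter above it.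

The next compound, compound 4 `Oc1cccc(-c2cc(-c3ccco3)nc(-c3ccccc3Cl)c2)c1`, has not yet been measured in this assay. It differs from compound 3 in one place: furan-2-yl in place of pyridin-4-yl on an aromatic carbon.

Within the data shown here, no two measured compounds differ in only one place, so no measured step guides this change directly. Among the measured compounds shown here, the only measured compound carrying a furan-2-yl group is compound 2, whose 27.1% in this assay is the highest of the three, but compound 2 also differs from compound 3 elsewhere, so that number is only a loose pointer. In this assay the expected step is a number 10 percentage points higher from compound 3 to compound 4 (within the scatter). Compound 4 is expected to give roughly 10% in this assay, with the estimate running from 0% to 30%.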

Compound 4, a percentage reported as inhibition, at one concentration (the size of the read-out at that concentration, not a potency): 0%
Compound 4: middle estimate off by 10 percentage points, on the high side; measured number inside the range.
By their numbers in this assay, from the lowest: compounds 3, 4 and 1 (each within the scatter of the next); then compound 2.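

In this assay, placing furan-2-yl instead of pyridin-4-yl next to the ring nitrogen gives no change at the digits printed from compound 3 to compound 4 (within the scatter) and so shows no measurable effect of this ring exchange when a 2-chlorophenyl group sits on the core. Among these compounds, the furan-2-yl group is therefore not enough on its own to give the higher reading of compound 2, and the chlorophenyl group turns out to matter: having 2-chlorophenyl in place of 4-chlorophenyl gives a number 27.1 percentage points lower from compound 2 to compound 4 (beyond the scatter) and is the one single change in this set that goes beyond the scatter. Nothing available explains either step.

As far as these compounds go, it remains open whether the exchange of pyridin-4-yl for furan-2-yl would still make no difference with a 4-chlorophenyl group on the core, where the reading starts higher. From the compounds shown here alone, it is also open how a 3-chlorophenyl group would read at the chlorophenyl position, or how an amine or a carboxylic acid would read in the place held by the furan-2-yl group.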